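Cyclopropylurea versus propylamine on the shared benzothiazole-like core

The compounds below may be only part of what the source reports. "The series", "measured", "known", "first", "only" and "open" are said of these compounds alone.

Among the measured compounds shown here, compound 1 `COc1ncc(-c2ccc3nc(NC(=O)NC4CC4)sc3c2)cc1NS(=O)(=O)c1ccc(F)cc1` is the one anchor with a number: in a functional assay on MCF7 cells (Homo sapiens) for antiproliferative activity, read by MTT assay, with a stated time of 72 h (on this read-out higher numbers stand for weaker inhibition and lower numbers for stronger inhibition), compound 1 gives 1190 nM. Compound 2 `CCCNc1nc2ccc(-c3cnc(Cl)c(NS(=O)(=O)c4ccc(F)cc4)c3)cc2s1` was taken into this assay, but for compound 2 the entry reads "not determined" (no result reported), so compound 2 stands nowhere on the numbers shown and no step from it can be sized. Compound 3 `O=C(Nc1nc2ccc(-c3cnc(Cl)c(NS(=O)(=O)c4ccc(F)cc4)c3)cc2s1)NC1CC1` is to be measured in this assay. Compound 3 differs from compound 2 by cyclopropylcarbamoyl in place of propyl on a nitrogen on an aromatic ring; the same difference, cut one bond further out, reads propylamino to (cyclopropylcarbamoyl)amino. With no number for compound 2, the size and direction of the step from compound 2 to compound 3 in this assay cannot be stated from these data. For the measured compounds named here, compound 1 carries the same (cyclopropylcarbamoyl)amino group on its core and is the only guide. Compound 3 is therefore expected near 1000 nM, with a range of 300 nM to 4000 nM.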

Compound 3, half-maximal inhibitory concentration: 1090 nM
The estimate for compound 3 lay 1.1-fold (0.04 log units) below the measured number; measured number inside the range.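

In this assay, the exchange of methoxy for chloro on an aromatic carbon, with the (cyclopropylcarbamoyl)amino group common to both compounds, gives a 1.1-fold lower number from compound 1 to compound 3 (0.04 log units; within the scatter), so this pair does not separate the two substituents at this position. The step from propylamino to (cyclopropylcarbamoyl)amino still cannot be read, since compound 2 has no number, and the contribution of the urea-bearing group remains unsized. No supporting data bear on why chloro and methoxy read alike here.

Open, on these data alone, is whether a nitrile, a fluoro group or a plain hydrogen on that aromatic carbon would also stay within the scatter of this pair. Also open, as far as these compounds go, is how an amine or a longer chain in place of the cyclopropyl group would read in this assay.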